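A few compounds are considered here, and "the series" means these few. Any claim that something is new, unique, unknown or untested is made for them only; others in the source may bear on it.

Among the compounds with values here, the three compounds measured so far share the core of compound 1 `O=C(/C=C/c1ccc2c(c1)B(O)OC2)c1cccs1` and differ only in the group on the carbonyl carbon. In a toxicity assay on WI-38 cells (Homo sapiens) for cytotoxicity, read by MTT assay, with a stated time of 48 h (a higher number here means a weaker inhibitor, a lower number a stronger inhibitor), compound 1 gives 26000 nM. Compound 3 `O=C(/C=C/c1ccc2c(c1)B(O)OC2)c1ccc(Br)cc1`, which carries a 4-bromophenyl there, gives 36700 nM in this assay, the higher of the two numbers shown, although the step of a 1.4-fold higher number from compound 1 to compound 3 (0.15 log units; within the scatter) lies within the scatter. For compound 2 `Cn1cccc1C(=O)/C=C/c1ccc2c(c1)B(O)OC2` this assay reports only a limit, > 100000 nM. From that limit follow an at least 3.8-fold higher number from compound 1 to compound 2 (0.58 log units; beyond the scatter) and an at least 2.7-fold lower number from compound 2 to compound 3 (0.43 log units; beyond the scatter), both resting on (the limit of > 100000 nM in this assay, at which 1 of the 3 values shown sits).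

Compound 4 `O=C(/C=C/c1ccc2c(c1)B(O)OC2)c1ccc(OCc2ccccc2)cc1` differs from compound 3 by benzyloxy in place of bromo on an aromatic carbon. Within the data shown here, none of the measured steps alters a substituent on the six-membered aromatic ring of carbon only; all three exchange the whole group on the carbonyl carbon, and the single step between two numbers, a 1.4-fold higher number from compound 1 to compound 3 (0.15 log units; within the scatter), was within the scatter, while the two steps involving compound 2 end at a limit. Among the measured compounds shown here, no measured step therefore speaks directly to this change, so a step of no size beyond the scatter is the plainest expectation, with wide uncertainty. Compound 4 is expected to give 30000 nM in this assay. For compound 4 the estimate spans 9000 nM to 100000 nM, which is expected to amount to a 1.2-fold lower number from compound 3 to compound 4 (0.09 log units; within the scatter).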

Compound 4, half-maximal inhibitory concentration: > 100000 nM
Compound 4 was reported as a limit; the forecaster's own chance of this, stated with the estimate: 25%; at least 3.3-fold (0.52 log units) between middle value and limit.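

In this assay compound 4 is recorded only as a limit, > 100000 nM, and not as a number. Even so, the change gives an at least 2.7-fold higher number from compound 3 to compound 4 (0.43 log units; beyond the scatter), so this is the first measured step that alters only a substituent on the six-membered aromatic ring of carbon only, rather than the whole group on the carbonyl carbon, and it shows that exchanging bromo for benzyloxy on this aromatic carbon, para to a large group, moves the reading beyond the scatter. The true size of this step cannot be read, and only its lower bound is known, which rests on the assay's ceiling: the limit of > 100000 nM in this assay, at which 2 of the 4 values shown sit.

The compounds shown leave open how far compound 4 actually lies from compound 3, and whether the step follows the oxygen of the benzyloxy group or its added aromatic ring. A methoxy group or an amine on the same aromatic carbon would be needed to tell whether a reading stays close to that of compound 3 or also ends at the limit.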